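The source may hold more compounds than are shown below. What is called first, only, known or untested is meant among the compounds shown, and "the series" means these compounds.

Measured compounds:
compound 1, `C[C@@H](C(=O)O)c1nn(Cc2cn3cc(OCC4CC4)c(Cl)cc3n2)c2ccccc2c1=O` — in an ADME assay on microsomes from liver (Mus musculus) for metabolic stability (on this read-out lower numbers stand for slow clearance and higher numbers for fast clearance), compound 1 gives < 55 mL/min/kg, a limit of the assay and not a number.
compound 2, `CCC(C(=O)O)c1nn(Cc2cn3cc(OCC4CC4)c(Cl)cc3n2)c2ccccc2c1=O` — in this assay compound 2 gives < 56.7 mL/min/kg, likewise a limit.
compound 3, `CC(C)(C(=O)O)c1nn(Cc2cn3cc(OCC4CC4)c(Cl)cc3n2)c2ccccc2c1=O` — in this assay compound 3 gives < 63.4 mL/min/kg, likewise a limit.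

Compound 3 therefore stands only at a limit in this assay (the limit of < 63.4 mL/min/kg in this assay, at which 1 of the 3 values shown sits), and the two other values shown are limits as well (the limit of < 55 mL/min/kg in this assay, at which 1 of the 3 values shown sits, (the limit of < 56.7 mL/min/kg in this assay, at which 1 of the 3 values shown sits)). Compound 4, `O=C(O)C1(c2nn(Cc3cn4cc(OCC5CC5)c(Cl)cc4n3)c3ccccc3c2=O)CC1`, is not yet measured; it differs from compound 3 by 1-carboxycyclopropyl in place of 1-carboxy-1-methylethyl on an aromatic carbon. Among the measured compounds shown here, the steps that bear on this change, a step that the two limits leave unreadable from compound 1 to compound 2, a step that the two limits leave unreadable from compound 1 to compound 3 and a step that the two limits leave unreadable from compound 2 to compound 3, all have a size that cannot be read, since both ends sit at limits. No step beyond the scatter is expected in this assay, in either direction. For compound 4 the expected value is 40 mL/min/kg, with a range from 15 mL/min/kg to 63 mL/min/kg. The step this estimate means is expected to be a step that the limit leaves unreadable from compound 3 to compound 4.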

Compound 4, clearance: < 53.4 mL/min/kg
Compound 4: no number, only a limit; the forecaster's own chance of this, stated with the estimate: 70%; the middle value does not contradict the limit.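

In this assay, among the compounds shown here, compound 1, compound 2, compound 3 and compound 4 all stand only at limits, so no step to compound 4 can be read. The compounds shown leave open whether 1-carboxycyclopropyl differs at all from the other three groups in clearance.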